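Compound 3 to compound 4: one aromatic group exchanged

The compounds below may be only part of what the source reports. "The series", "measured", "known", "first", "only" and "open" are said of these compounds alone.

In a functional assay on MDA-MB-436 cells (Homo sapiens) for antiproliferative activity, read by MTT assay, with a stated time of 48 h (a higher number here means a weaker inhibitor, a lower number a stronger inhibitor), compound 1 `C=CS(=O)(=O)N1CCN(c2ncnc3sc(-c4ccc(C(F)(F)F)cc4)cc23)CC1` gives 7080 nM, compound 2 `C=CS(=O)(=O)N1CCN(c2ncnc3sc(-c4cccc5ncccc45)cc23)CC1` gives 25900 nM and compound 3 `C=CS(=O)(=O)N1CCN(c2ncnc3sc(-c4ccnc(Cl)c4)cc23)CC1` gives 30100 nM. Compound 3 thus stands at the high end of the three numbers, level with compound 2 and above compound 1. Replacing 4-(trifluoromethyl)phenyl gave a 3.7-fold higher number from compound 1 to compound 2 (0.56 log units; beyond the scatter) and a 4.3-fold higher number from compound 1 to compound 3 (0.63 log units; beyond the scatter), both modest. Exchanging quinolin-5-yl for 2-chloropyridin-4-yl gave a 1.2-fold higher number from compound 2 to compound 3 (0.07 log units; within the scatter).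

Compound 4 `C=CS(=O)(=O)N1CCN(c2ncnc3sc(-c4c(C)noc4C)cc23)CC1` keeps the shared core and carries 3,5-dimethyl-1,2-oxazol-4-yl in place of 2-chloropyridin-4-yl on an aromatic carbon, next to the ring sulfur (3,5-dimethyl-1,2-oxazol-4-yl in place of 2-chloropyridin-4-yl on an aromatic carbon). For the measured compounds named here, no measured step involves this group, so the evidence is indirect. Going by the values given here, the closest precedent is the exchange that gave a 1.2-fold higher number from compound 2 to compound 3 (0.07 log units; within the scatter), which suggests little movement when one nitrogen-containing aromatic group replaces another. The modest steps of a 3.7-fold higher number from compound 1 to compound 2 (0.56 log units; beyond the scatter) and a 4.3-fold higher number from compound 1 to compound 3 (0.63 log units; beyond the scatter) mark the largest change seen so far at this position. In this assay no step beyond the scatter is expected, with any drift more likely toward a lower number, since the series offers only lower values than that of compound 3. The estimated step is a 1.5-fold lower number from compound 3 to compound 4 (0.18 log units; within the scatter). For compound 4 the expected value is 20000 nM, with an estimated range from 8000 nM to 50000 nM.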

Compound 4, half-maximal inhibitory concentration: 34600 nM
Compound 4: middle estimate off by 1.7-fold (0.24 log units), on the low side; measured number inside the range.
By their numbers in this assay, from the lowest: compound 1; then compounds 2, 3 and 4 (each within the scatter of the next).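

In this assay, 3,5-dimethyl-1,2-oxazol-4-yl cannot be separated from 2-chloropyridin-4-yl (a 1.1-fold higher number from compound 3 to compound 4 (0.06 log units; within the scatter)) or from quinolin-5-yl (a 1.3-fold higher number from compound 2 to compound 4 (0.13 log units; within the scatter)). At this aromatic carbon next to the ring sulfur, a five-membered aromatic ring with 2 hetero atoms therefore reads the same as the six-membered ring it replaces, and all three groups with a ring nitrogen now sit together, apart from the 4-(trifluoromethyl)phenyl of compound 1 (a 4.9-fold higher number from compound 1 to compound 4 (0.69 log units; beyond the scatter)), with no exception among the four compounds. No measurement here gives a reason for this separation.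

From the compounds shown here alone, whether the lower number of compound 1 goes with the trifluoromethyl group or with a phenyl ring free of ring hetero atoms stays open, and an unsubstituted phenyl or a 4-methoxyphenyl would be needed to tell these apart. Also open is whether a phenyl ring carrying an amine or a carboxylic acid would reach a lower number than compound 1, which gives 7080 nM, the lowest number shown.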